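Two Epimers at the Limit of a Cytotoxicity Assay

The source may hold more compounds than are shown below. What is called first, only, known or untested is meant among the compounds shown, and "the series" means these compounds.

Measured in a functional assay on SK-OV-3 cells (Homo sapiens) for cytotoxicity, read by MTT assay (a lower number here means a stronger inhibitor, a higher number a weaker inhibitor), so far, each value a limit of the assay:
compound 1 `C/C1=C/C2=C(CC(C)(C)[C@H]2O)[C@H](C)CC[C@@H]1O` gives > 10 ug/mL (a limit)
compound 2 `C/C1=C/[C@]23O[C@]2(CC(C)(C)C3=O)[C@H](C)CC[C@@H]1O` gives > 10 ug/mL (a limit)
compound 3 `C/C1=C/C2=CC(C)(C)C[C@@]2(OO)[C@H](C)CC[C@@H]1O` gives > 10 ug/mL (a limit)

The three compounds show the limit of > 10 ug/mL in this assay, at which 3 of the 3 values shown sit, and so offer no number by which they could be ranked. Compound 3 gives > 10 ug/mL in this assay and this is a limit, not a measured potency.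

The next compound to be tested is compound 4 `C/C1=C/C2=CC(C)(C)C[C@]2(OO)[C@H](C)CC[C@@H]1O` and it departs from compound 3 in one way only: the two compounds have the same atoms and bonds and differ only in configuration as drawn: 1 of 4 stereo elements differ; a stereocentre at a saturated ring carbon is drawn R in compound 3 and S in compound 4. Its atoms and bonds are unchanged, and a stereocentre at a saturated ring carbon is drawn R in compound 3 and S in compound 4.

Going by the values given here, no measured pair in this set shows what such a change does. The expectation therefore rests on compound 3 (> 10 ug/mL as a limit) and on the unchanged atoms and bonds. The expected step is a step that the limit leaves unreadable from compound 3 to compound 4, which is read against a limit and implies no change beyond the scatter in either direction. Most likely the assay will again report only a limit. Should a number appear, the estimate for compound 4 is 12 ug/mL, with an expected range from 6 ug/mL to 30 ug/mL.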

Compound 4, half-maximal inhibitory concentration: > 10 ug/mL
Compound 4: a limit, no number (the forecaster's own chance of this, stated with the estimate: 70%); the middle value is on the limit's open side.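

Going by these compounds alone, compound 3 and compound 4 both give only a limit in this assay, so no step between them can be read. The compounds shown leave open whether the configuration at that saturated ring carbon has any bearing on the read-out in this assay, and how compound 1, compound 2, compound 3 and compound 4 would rank against one another.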